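Thiophenyl in Place of Ethynyl on a Shared Nucleoside Core

A few compounds are considered here, and "the series" means these few. Any claim that something is new, unique, unknown or untested is made for them only; others in the source may bear on it.

Compound 1 `Cc1nc(N)c2c(-c3ccccc3)cn([C@@H]3O[C@H](CO)[C@@H](O)[C@H]3O)c2n1`, compound 2 `C#Cc1cn([C@@H]2O[C@H](CO)[C@@H](O)[C@H]2O)c2nc(C)nc(N)c12` and compound 3 `Nc1nc2c(c(-c3ccoc3)cn2[C@@H]2O[C@H](CO)[C@@H](O)[C@H]2O)c(=O)[nH]1` share one core and were tested in a functional assay on A549 cells (Homo sapiens), read by MTT assay, with a stated time of 72 h; a lower number here means a stronger inhibitor, a higher number a weaker inhibitor. In this assay compound 1 reaches only the assay limit of > 20000 nM. Compound 2 likewise stops at the limit of > 20000 nM. Compound 3 too sits at the limit of > 20000 nM. The step that the two limits leave unreadable from compound 1 to compound 2 is therefore not readable. Compound 4 `Cc1nc(N)c2c(-c3ccsc3)cn([C@@H]3O[C@H](CO)[C@@H](O)[C@H]3O)c2n1` differs from compound 2 by thiophen-3-yl in place of ethynyl on an aromatic carbon. No readable measured step bears on this change; all three measured values sit at the limit, as the limit of > 20000 nM in this assay, at which 3 of the 3 values shown sit, records. Compound 4 is expected to remain at or near the limit, with an expected step that the limit leaves unreadable from compound 2 to compound 4. The estimate for compound 4 is 30000 nM, ranging from 8000 nM to 100000 nM.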

Compound 4, half-maximal inhibitory concentration: > 20000 nM
Compound 4 ended at the assay's limit (the forecaster's own chance of this, stated with the estimate: 85%); the middle value does not contradict the limit.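

No step can be read between compound 4, compound 1 and compound 2, as all sit at a limit in this assay: the limit of > 20000 nM in this assay, at which 4 of the 4 values shown sit.

The compounds shown leave open whether any group at this place on the shared core alters inhibition.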